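The compounds below may be only part of what the source reports. "The series", "measured", "known", "first", "only" and "open" are said of these compounds alone.

In a functional assay on PC-3 cells (Homo sapiens) for inhibition, read by sulforhodamine B assay, with a stated time of 48 h (a higher number here means that more compound is tolerated, a lower number that less compound is tolerated), compound 2, whose structure is `COc1cc(-c2nn(-c3cccc(NC(=O)Nc4cc(C(F)(F)F)cc(C(F)(F)F)c4)c3)cc2-c2ccncc2)ccc1Cl`, gives > 50000 nM, which is a limit of the assay rather than a number. Compound 3, with the structure `COc1cc(-c2nn(-c3cccc(NC(=O)Nc4cccc(C(F)(F)F)c4)c3)cc2-c2ccncc2)ccc1Cl`, gives > 50000 nM, again a limit. Compound 1, with the structure `O=C(Nc1cccc(-n2cc(-c3ccncc3)c(-c3ccc(Cl)c(O)c3)n2)c1)Nc1cccc(C(F)(F)F)c1`, gives > 32500 nM, also a limit. Compound 2 thus stands at the limit of > 50000 nM in this assay, at which 2 of the 3 values shown sit, and compound 1 sits at the limit of > 32500 nM in this assay, at which 1 of the 3 values shown sits.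

The unmeasured compound 4, with the structure `O=C(Nc1cccc(-n2cc(-c3ccncc3)c(-c3ccc(Cl)c(O)c3)n2)c1)Nc1cc(C(F)(F)F)cc(C(F)(F)F)c1`, differs from compound 2 by hydrogen in place of methyl on an oxygen on an aromatic ring. For the measured compounds named here, two measured steps bear on this change. The step that the two limits leave unreadable from compound 1 to compound 3 covers the same exchange in the opposite direction, and the step that the two limits leave unreadable from compound 2 to compound 3 covers hydrogen in place of trifluoromethyl on an aromatic carbon; neither can be read, since every end point is a limit. Going by the values given here, no step of readable size is available, so no change beyond the scatter is expected, and the expected step is a number no higher from compound 2 to compound 4 (the limit leaves the size open). Compound 4 is expected to give about 50000 nM in this assay, within a range from 20000 nM to 150000 nM, most likely once more reported only as a limit.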

Compound 4, concentration lethal to 50% of the cells: > 50000 nM
Compound 4: a limit, no number; the forecaster's own chance of this, stated with the estimate: 80%; the middle value lies on the limit itself.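

No new step can be read: compound 4, like compound 1 and compound 2, is reported only as a limit, so its steps from those two compounds stay unreadable. The compounds shown leave open whether methoxy to hydroxy, or trifluoromethyl in place of hydrogen, changes the result in this assay at all.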